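The source may report more compounds than this note shows. Statements on the series, on what has been measured and on what is new or still open speak of the compounds shown alone.

In a physicochemical assay for solubility, read by spectrophotometry, in phosphate buffer, with a stated time of 18 h, at pH 7.4 (on this read-out lower numbers stand for lower solubility and higher numbers for higher solubility), two compounds sharing one core have been measured. Compound 1 `CCc1ccc(-c2nc3c(c(C)nn3-c3ccccc3)c(-c3ccccc3F)c2C#N)cc1` gives 1700 nM, and compound 2 `CCc1ccc(-c2nc3c(c(C)nn3-c3ccccc3)c(-c3cccc(O)c3)c2C#N)cc1` gives 18000 nM, the higher of the two numbers. The next compound to be read is compound 3 `CCc1ccc(-c2nc3c(c(C)nn3-c3ccccc3)c(-c3ccccc3C(=O)OC)c2C#N)cc1`, in which 2-(methoxycarbonyl)phenyl takes the place of the 3-hydroxyphenyl of compound 2, on the aromatic carbon ortho to a cyano group and opposite the ring nitrogen: 2-(methoxycarbonyl)phenyl in place of 3-hydroxyphenyl on an aromatic carbon. Among the measured compounds shown here, only one measured step bears on this change: an 11-fold higher number from compound 1 to compound 2 (1.02 log units; beyond the scatter), a large step beyond the scatter, in which 3-hydroxyphenyl replaced 2-fluorophenyl at this same place. Compound 3 gives up the 3-hydroxyphenyl as well, so a return towards compound 1 at 1700 nM seems the likeliest outcome. For the measured compounds named here, this rests on a single step, and 2-(methoxycarbonyl)phenyl itself has no measured precedent here. A clear fall beyond the scatter is therefore expected in this assay, with the expected step of a 5.1-fold lower number from compound 2 to compound 3 (0.71 log units; beyond the scatter). The estimate for compound 3 is 3500 nM, with an expected range from 900 nM to 12000 nM.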

Compound 3, solubility: 17000 nM
The estimate for compound 3 lay 4.9-fold (0.69 log units) below the measured number; the measured number lies above the stated range.
By their numbers in this assay, from the lowest: compound 1; then compounds 3 and 2 (each within the scatter of the next).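

The result shows that a hydroxyl is not needed at this place to keep the higher number in this assay: with a 1.1-fold lower number from compound 2 to compound 3 (0.02 log units; within the scatter), the step to 2-(methoxycarbonyl)phenyl, which has no hydrogen-bond donor, stays within the scatter. Compound 1 is therefore the one that stands apart among these three, and a 10-fold higher number from compound 1 to compound 3 (1.00 log units; beyond the scatter) shows that methoxycarbonyl in place of fluoro on the same phenyl ring accounts for a change beyond the scatter, so a substituent at the 2-position of this ring does not by itself go with the low number. No measurement shown here explains why these two different groups read alike or why 2-fluorophenyl differs from them.

The compounds shown leave open whether the hydroxyl and the methyl ester have any separate contribution, which a plain phenyl ring at this place could test against both. They also leave open how a carboxylic acid or a primary amide at the 2-position, or the methyl ester moved to the 3-position, would read.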